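A few compounds are considered here, and "the series" means these few. Any claim that something is new, unique, unknown or untested is made for them only; others in the source may bear on it.

Three compounds share one core and are measured in a functional assay on DU-145 cells (Homo sapiens) for inhibition; on this read-out lower numbers stand for stronger inhibition and higher numbers for weaker inhibition. Compound 1 `Oc1cccc(-c2cc(-c3ccc(F)cc3)cc(-c3ccccc3O)n2)c1` reaches only the limit of the assay, > 50000 nM, not a number. Compound 2 `Oc1ccc(-c2cc(-c3ccc(F)cc3)cc(-c3ccccc3O)n2)cc1` likewise gives only the limit, > 50000 nM. Compound 3 `Oc1ccc(-c2cc(-c3ccc(F)cc3)cc(-c3ccc(O)cc3)n2)cc1` gives a number, 6030 nM. Between two limits the step that the two limits leave unreadable from compound 1 to compound 2 cannot be read; the step of an at least 8.2-fold lower number from compound 2 to compound 3 (0.91 log units; beyond the scatter) is readable and lies beyond the scatter. Compound 4 `Oc1ccc(-c2cc(-c3ccc(OC(F)(F)F)cc3)cc(-c3ccccc3O)n2)cc1` differs from compound 2 by trifluoromethoxy in place of fluoro on an aromatic carbon. Among the compounds with values here, no measured step touches this change, and compound 2 stands at the limit (the limit of > 50000 nM in this assay, at which 2 of the 3 values shown sit), so the starting point itself is only a boundary. The expectation for compound 4 in this assay is therefore 60000 nM, within 15000 nM to 200000 nM, a step that the limit leaves unreadable from compound 2 to compound 4 that is a guess rather than a trend.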

Compound 4, half-maximal inhibitory concentration: > 50000 nM
Compound 4: only a limit was reported (the forecaster's own chance of this, stated with the estimate: 70%); the middle value is on the limit's open side.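

Within the data shown here, compound 2 and compound 4 both give only a limit rather than a number, so no step between them can be read: the limit of > 50000 nM in this assay, at which 3 of the 4 values shown sit. The compounds shown leave open whether trifluoromethoxy in place of fluoro changes inhibition at all.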